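Removing cyano from compound 1: working notes

The source may hold more compounds than are shown below. What is called first, only, known or untested is meant among the compounds shown, and "the series" means these compounds.

Values in an ADME assay on microsomes from liver (Mus musculus) for metabolic stability, read by LC-MS, using NADPH, tested at 1 uM; a higher number here means faster removal of the compound, a lower number slower removal:
- compound 1 `Cc1cnc(NC(=O)CCCOc2cccc(C#N)c2)s1` gives 460 mL.min-1.g-1
- compound 2 `Cc1cnc(NC(=O)CCCOc2cccc(Cl)n2)s1` gives > 866 mL.min-1.g-1 as a limit of the assay
- compound 3 `Cc1cnc(NC(=O)CCCOc2cncc(Cl)c2)s1` gives 308 mL.min-1.g-1

Compound 1 (460 mL.min-1.g-1) and compound 3 (308 mL.min-1.g-1) lie within the usual scatter of each other in this assay. The only other result is the limit for compound 2 (> 866 mL.min-1.g-1), so compound 1 has a single numerical neighbour.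

The next compound is compound 4 `Cc1cnc(NC(=O)CCCOc2ccccc2)s1`, which differs from compound 1 at one place (hydrogen in place of cyano on an aromatic carbon): hydrogen in place of cyano on an aromatic carbon.

Within the data shown here, no step at a single place has been measured, so there is no direct precedent for its size. A change no larger than the scatter is expected, with a slight lean towards faster removal. The expected change runs a 1.1-fold higher number from compound 1 to compound 4 (0.05 log units; within the scatter) in this assay. For compound 4 the estimated value is 520 mL.min-1.g-1 (expected range 230 mL.min-1.g-1 to 1100 mL.min-1.g-1).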

Compound 4, intrinsic clearance in microsomes: 815 mL.min-1.g-1
Compound 4: middle estimate off by 1.6-fold (0.20 log units), on the low side, within the range that was stated.
By their numbers in this assay, from the lowest: compounds 3, 1 and 4 (each within the scatter of the next, the first and the last beyond it). At a limit, above all of these: compound 2.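

Hydrogen in place of cyano on an aromatic carbon is the first step at a single place in this series, and in this assay it gives a 1.8-fold higher number from compound 1 to compound 4 (0.25 log units; within the scatter). At this place on the six-membered aromatic ring of carbon only, the nitrile can therefore be lost without a change that stands clear of the scatter, though this single pair sets no pattern. Compound 2 stays a limit of the assay and not a number, so it adds no step to this reading: the limit of > 866 mL.min-1.g-1 in this assay, at which 1 of the 4 values shown sits.

Compound 2 and compound 3 each differ from compound 4 at more than one place, so the share of their chlorine and of their ring nitrogen remains unseparated. Also open, going by these compounds, is whether a methoxy group, a trifluoromethyl group or an amine at this same place would give a step beyond the scatter in this assay.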